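The source may hold more compounds than are shown below. What is called first, only, known or untested is meant among the compounds shown, and "the series" means these compounds.

Of the compounds shown here, two have been measured in a functional assay on A-375 cells (Homo sapiens) for antiproliferative activity, read by CCK-8 assay, with a stated time of 72 h, tested at 2 uM; a lower number here means a weaker effect, a higher number a stronger effect of the compound at the concentration tested. Compound 1, with the structure `Nc1ccccc1NC(=O)c1ccc(CSC(=S)N2CCN(c3ccccc3)CC2)cc1`, gives 27.5%. Compound 2, with the structure `Nc1ccccc1NC(=O)c1ccc(CSC(=S)N2CCc3ccccc32)cc1`, gives 25.7%. The two numbers lie within the usual scatter of each other, so compound 1 and compound 2 cannot be set apart on these data; neither can be called the more active of the pair.

Compound 3, with the structure `Nc1ccccc1NC(=O)c1ccc(CSC(=S)N2CCN(c3ccccc3F)CC2)cc1`, has not yet been measured. Compared with compound 1, the change is fluoro in place of hydrogen on an aromatic carbon. Everything else in the molecule is kept.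

Going by the values given here, no measured pair here differs in a single place, so there is no measured step to lean on. Judged only from what compound 1 gives, a fluoro atom entering in place of a hydrogen on an aromatic carbon is a small change, and the step from compound 1 to compound 3 in this assay is expected to be a number 0.5 percentage points higher from compound 1 to compound 3 (within the scatter), that is, not beyond the scatter in either direction. On that basis compound 3 is estimated to give 28% in this assay, within a range from 15% to 42%.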

Compound 3, a percentage reported as inhibition, at one concentration (the size of the read-out at that concentration, not a potency): 18.7%
Compound 3: middle estimate off by 9.3 percentage points, on the high side; low and high end bracket the measured number.
By their numbers in this assay, from the lowest: compounds 3, 2 and 1 (each within the scatter of the next).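

Going by these compounds alone, the phenyl to 2-fluorophenyl change gives the first step here that can be read at a single place in the molecule, and in this assay it is a number 8.8 percentage points lower from compound 1 to compound 3 (within the scatter), so a fluoro on this aromatic carbon, ortho to a large group, cannot be said to help or to harm. What the step does show is that this one-atom replacement leaves the read-out inside the range that repeated measurements would be expected to cover, which a comparison of the two earlier compounds could not show, since they differ in more than one place. Nothing available explains the size of this step, and no outside measurement bears on it.

As far as these compounds go, it remains open whether a larger or different group on this same carbon, such as chloro, methoxy or an amine, would give a step beyond the scatter. It is also open whether a fluoro on another carbon of this ring would read the same way, and a single tested concentration gives no potency for any of these compounds.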